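A few compounds are considered here, and "the series" means these few. Any claim that something is new, unique, unknown or untested is made for them only; others in the source may bear on it.

Compound 1 `O=S1(=O)N=C(NCC2CCCCC2)Nc2ncccc21` and compound 2 `O=S1(=O)N=C(NCc2ccccc2)Nc2ncccc21` share one core; compound 3 `C[C@@H](NC1=NS(=O)(=O)c2cc(Cl)cnc2N1)C1CCCCC1` carries a different core, and how the two cores differ is not broken down here. In a functional assay (aorta) with Rattus norvegicus as the target (a higher number here means that more compound is needed for the effect, a lower number that less compound is needed), compound 1 gives 45.7 uM, while compound 2 gives 21.9 uM, so the change phenyl in place of cyclohexyl on a saturated chain carbon bound to an amine nitrogen brought a 2.1-fold lower number from compound 1 to compound 2 (0.32 log units; beyond the scatter). Compound 3 gives 3.5 uM in this assay. Compound 4 `C[C@@H](NC1=NS(=O)(=O)c2cc(Cl)cnc2N1)c1ccccc1` is the same kind of change made on compound 3, (phenyl in place of cyclohexyl on a saturated chain carbon bound to an amine nitrogen and a saturated chain carbon); the place differs in that this saturated chain carbon is bound to an amine nitrogen and a saturated chain carbon, not only to an amine nitrogen. Resting on that one earlier step, a modest lowering of the number, the step from compound 3 to compound 4 is expected to be about a 2.1-fold lower number from compound 3 to compound 4 (0.31 log units; beyond the scatter). Compound 4 is therefore estimated at 1.7 uM, most likely between 0.7 uM and 4.5 uM.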

Compound 4, concentration for half-maximal effect: 38.8 uM
Beside the measured number, compound 4's estimate is 23-fold (1.36 log units) below it; the whole stated range lies below it.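

In this assay, placing phenyl where cyclohexyl stood gave an 11-fold higher number from compound 3 to compound 4 (1.04 log units; beyond the scatter), the opposite direction to the earlier step. The effect of this change therefore did not carry over from one core to the other: the same change on two cores in this assay, a 2.1-fold lower number (0.32 log units; beyond the scatter) from compound 1 to compound 2 and an 11-fold higher number (1.04 log units; beyond the scatter) from compound 3 to compound 4, 23-fold (1.36 log units) apart, beyond the scatter of two such steps This does not show what sets the two steps apart, as the pairs differ both in their cores and in what the saturated chain carbon is bound to, and two pairs give no general rule.

The compounds shown leave open whether the core or the substitution on that chain carbon matters more. Also open, going by these compounds, is how a longer chain or a pyridyl group would behave in place of phenyl on either core.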